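From 2-Chlorophenyl to 4-Chlorophenyl: An Expected Small Step

This account rests on a few compounds, and the source may have more. Where it says the series, first, only, none or still open, it means among the compounds named here.

Of the compounds shown here, two that share a core have so far been measured in a physicochemical assay for metabolic stability, read by LC-MS, in simulated gastric fluid, with a stated time of 15 min, tested at 50 uM; a higher number here means that more of the compound is left, a lower number that less of the compound is left. Compound 1 (`COc1ccc(CNC(=O)c2c(C)nc3cc(C)ccn23)cc1`) gives 100%. Compound 2 (`Cc1ccn2c(C(=O)NCc3ccccc3Cl)c(C)nc2c1`) gives 97.2%, so the two values lie within the usual scatter of each other and neither can be ranked ahead of the other. Among the measured compounds shown here, no measured pair differs in one place only, which leaves no direct precedent for a single structural change.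

Compound 3 (`Cc1ccn2c(C(=O)NCc3ccc(Cl)cc3)c(C)nc2c1`) has not yet been measured. It carries 4-chlorophenyl in place of 2-chlorophenyl on a saturated chain carbon bound to an amide-type nitrogen. The exchange keeps the same atoms, joined differently.

With compound 1 at 100% and compound 2 at 97.2%, the available values give no sign of a large change in this assay, although neither value tests this exchange directly. The expected change is a number 0.2 percentage points lower from compound 2 to compound 3 (within the scatter), which would be no step beyond the scatter. For compound 3 the estimated value is 97%, with an expected range from 88% to 100%.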

Compound 3, percent of the compound remaining: 94.3%
Compound 3: the middle estimate sits 2.7 percentage points above what was measured, within the range that was stated.
By their numbers in this assay, from the lowest: compounds 3, 2 and 1 (each within the scatter of the next).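

In this assay, among the compounds shown here, 4-chlorophenyl in place of 2-chlorophenyl on a saturated chain carbon bound to an amide-type nitrogen gives a number 2.9 percentage points lower from compound 2 to compound 3 (within the scatter), which is the first direct reading of this exchange at this place, and it does not separate the two compounds. For the compounds shown here, the new compound also supplies a pair that the earlier compounds could not: chloro in place of methoxy on an aromatic carbon gives a number 5.7 percentage points lower from compound 1 to compound 3 (within the scatter), so this exchange cannot be told apart from repeat scatter either. Nothing available bears on the cause of these readings.

Among the compounds shown, the aromatic ring carries only chloro or methoxy, so it remains open whether an amine or a carboxylic acid on that ring, or a longer chain in place of the saturated chain carbon, would also read within the scatter in this assay. These readings also come from this single assay, so they leave open how the three compounds would behave under any other conditions.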